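The compounds below may be only part of what the source reports. "The series", "measured", "known", "first", "only" and "open" are said of these compounds alone.

In a functional assay on A2780 cells (Homo sapiens) for antiproliferative activity, read by CellTiter-Glo, with a stated time of 4 days (a lower number here means a stronger inhibitor, a higher number a weaker inhibitor), three compounds of differing structure have been measured. Compound 1 (`CC(=O)NCc1ncc2cc(COc3ccc(C(=O)NCc4cccnc4)cc3)n(CCC3CCCCC3)c2n1`) gives 15 nM, compound 2 (`O=C(NCc1cccnc1)Nc1ccc(CNC(=O)c2ccc(CN3CCNCC3)cc2)cc1`) gives 8 nM, and compound 3 (`C[C@H](NC(=O)C1CCOCC1)c1ccc(NC(=O)[C@H]2C[C@@H]2c2cccnc2)cc1`) gives 3 nM. Compound 3 thus holds the lowest of the three numbers, and its gaps to both of the others lie beyond the scatter.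

The next compound, compound 4 (`C[C@H](NC(=O)c1ccccn1)c1ccc(NC(=O)[C@H]2C[C@@H]2c2cccnc2)cc1`), keeps all of compound 3 except for one place, with pyridin-2-yl in place of oxan-4-yl on a carbonyl carbon. A non-aromatic six-membered ring thereby gives way to an aromatic one. Going by the values given here, no two measured compounds differ in only one place, so the data offer no direct precedent for this change. With compound 3 already the lowest at 3 nM, a small move toward a higher number in this assay is expected, possibly none beyond the scatter. The expected change is a 1.7-fold higher number from compound 3 to compound 4 (0.22 log units; within the scatter). For compound 4 the estimated value is 5 nM, with an expected range from 1.5 nM to 15 nM.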

Compound 4, half-maximal inhibitory concentration: 14 nM
For compound 4 the middle estimate is 2.8-fold (0.45 log units) below the measured one, and the stated range covers the measured number.
By their numbers in this assay, from the lowest: compound 3; then compounds 2, 4 and 1 (each within the scatter of the next).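

Going by these compounds alone, compound 4 supplies the first step in this assay that isolates a single place, the group on a carbonyl carbon whose other neighbour is an amide-type nitrogen. Putting pyridin-2-yl in place of oxan-4-yl there gives a 4.7-fold higher number from compound 3 to compound 4 (0.67 log units; beyond the scatter), so the number at this position depends on which ring is present, even though the two groups have the same heavy-atom, donor and acceptor counts and neither carries a net charge. Nothing available bears on the reason for this step.

The compounds shown leave open whether the step follows the change from a non-aromatic to an aromatic ring or the change of hetero atom from oxygen to nitrogen. Phenyl or piperidin-4-yl on the same carbonyl carbon would help separate these two changes.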